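The compounds below may be only part of what the source reports. "The series", "measured", "known", "first", "only" and "open" are said of these compounds alone.

Measured so far:
Compound 1, `COc1ccc(C(=O)/C=C/c2cccc(OCc3ccccc3)c2)cc1`: 19900 nM
Compound 2, `O=C(/C=C/c1cccc(OCc2ccccc2)c1)c1cccc(Br)c1`: 8300 nM

Both compounds were tested in a functional assay on ZR-75-1 cells (Homo sapiens) for cytotoxicity, read by MTT assay, with a stated time of 68 h; on this read-out lower numbers stand for stronger inhibition and higher numbers for weaker inhibition. Of the two numbers, compound 1 stands highest, and its nearest neighbour is compound 2, since a 2.4-fold lower number from compound 1 to compound 2 (0.38 log units; beyond the scatter). That step keeps the shared core and swaps only the aromatic group attached to the carbonyl carbon, 3-bromophenyl in place of 4-methoxyphenyl.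

The compound now in question is compound 3, `O=C(/C=C/c1cccc(OCc2ccccc2)c1)c1ccccc1`. It differs from compound 1 in one place: hydrogen in place of methoxy on an aromatic carbon. This is a smaller change than the step from compound 1 to compound 2, since the ring on the carbonyl carbon stays and only the methoxy group is removed.

Within the data shown here, only the single measured step bears on this, and it does so indirectly: it shows that replacing the 4-methoxyphenyl group with a different aryl group gave a lower number in this assay, but it does not test removal of the methoxy on its own. The expectation is therefore a step from compound 1 to compound 3 that is small, likely downward, and possibly within the scatter: a 1.7-fold lower number from compound 1 to compound 3 (0.22 log units; within the scatter). Compound 3 is estimated at 12000 nM, with a range from 5000 nM to 35000 nM.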

Compound 3, half-maximal inhibitory concentration: 8500 nM
Compound 3: middle estimate off by 1.4-fold (0.15 log units), on the high side; low and high end bracket the measured number.
By their numbers in this assay, from the lowest: compounds 2 and 3 (each within the scatter of the next); then compound 1.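

Taking away the methoxy and changing nothing else gives a 2.3-fold lower number from compound 1 to compound 3 (0.37 log units; beyond the scatter) in this assay, which isolates this group as a change that matters on its own; the earlier step could not do this, since it removed the 4-methoxyphenyl group and brought in a bromo at the same time. Hydrogen in place of bromo gives a 1.0-fold higher number from compound 2 to compound 3 (0.01 log units; within the scatter), so the 3-bromophenyl and phenyl compounds cannot be told apart here, and the step away from compound 1 needs no bromo: the plain phenyl ring does just as well among these three compounds. No measurement at hand explains why the methoxy compound has the highest number of the three.

Still open, from the compounds shown here alone, is whether it is the methoxy group itself that matters or its place on the ring, which 3-methoxyphenyl would help to separate from 4-methoxyphenyl. Also open, going by these compounds, is how other groups at this position would compare with hydrogen, bromo and methoxy, for example a hydroxyl, an amine or a carboxylic acid.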